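The source may report more compounds than this note shows. Statements on the series, on what has been measured and on what is new or still open speak of the compounds shown alone.

Series notes, compound 1 as the reference point. For the measured compounds named here, compound 1 `CCc1cc(NCc2cccnc2)n2ncc(Br)c2n1` is the strongest of the three compounds measured so far: in a functional assay on cells (Homo sapiens), read by thymidine incorporation (a higher number here means a weaker inhibitor, a lower number a stronger inhibitor), compound 1 gives 520 nM. Its two neighbours both carry a different group on the same aromatic carbon. Compound 2 `Brc1cnn2c(NCc3cccnc3)cc(C3CC3)nc12` gives 1500 nM, and compound 3 `CNc1cc(NCc2cccnc2)n2ncc(Br)c2n1` gives 1200 nM. The corresponding steps are a 2.9-fold higher number from compound 1 to compound 2 (0.46 log units; beyond the scatter) and a 2.3-fold higher number from compound 1 to compound 3 (0.36 log units; beyond the scatter), while the pair of neighbours lies close together, a 1.3-fold lower number from compound 2 to compound 3 (0.10 log units; within the scatter).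

Compound 4 `Brc1cnn2c(NCc3cccnc3)cc(C3CCCNC3)nc12` has not yet been measured. Against compound 1 it differs as follows: piperidin-3-yl in place of ethyl on an aromatic carbon. The change occupies the same place on the shared core as the two measured replacements of ethyl, so those two steps are the relevant ones. Going by the values given here, both were modest and both ran toward a higher number, with no example in the set of a replacement of ethyl at this carbon giving a lower number. Piperidin-3-yl is a larger group than either cyclopropyl or methylamino and brings a ring with a nitrogen, a hydrogen-bond donor and acceptor, which no measured compound tests.

The expectation for compound 4 is therefore a modest step toward a higher number, a 2.5-fold higher number from compound 1 to compound 4 (0.40 log units; beyond the scatter), with wide uncertainty because the group is outside what a 2.9-fold higher number from compound 1 to compound 2 (0.46 log units; beyond the scatter) and a 2.3-fold higher number from compound 1 to compound 3 (0.36 log units; beyond the scatter) cover. Compound 4 is estimated at 1300 nM, within 400 nM to 4500 nM.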

Compound 4, half-maximal inhibitory concentration: 60 nM
The estimate for compound 4 lay 22-fold (1.34 log units) above the measured number, outside the stated range (below it).
By their numbers in this assay, from the lowest: compound 4; then compound 1; then compounds 3 and 2 (each within the scatter of the next).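

This carbon is not limited to steps toward a higher number: in this assay, piperidin-3-yl in place of ethyl runs the other way, and by a wide margin (an 8.7-fold lower number from compound 1 to compound 4 (0.94 log units; beyond the scatter)). The same group also stands well apart from the two replacements that had looked alike (a 20-fold lower number from compound 3 to compound 4 (1.30 log units; beyond the scatter); a 25-fold lower number from compound 2 to compound 4 (1.40 log units; beyond the scatter)), so a ring at this carbon does not by itself give a low number, as cyclopropyl in compound 2 shows, and neither does a nitrogen in the entering group, as methylamino in compound 3 shows; within these four compounds, only the group combining a six-membered non-aromatic ring with a nitrogen gives a number this low. Nothing available bears on the reason for this step.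

The compounds shown leave open whether the gain belongs to the ring nitrogen or to the six-membered ring, a question that cyclohexyl at this carbon would address directly. Also open, on these data alone, is how much depends on where the nitrogen sits and on ring size, which piperidin-4-yl and pyrrolidin-3-yl would test against compound 4.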